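A few compounds are considered here, and "the series" means these few. Any claim that something is new, unique, unknown or untested is made for them only; others in the source may bear on it.

Measured in an ADME assay on the whole organism (plasma, Rattus norvegicus, strain Han-Wistar) for protein binding, read by LC-MS, at a dose of 1 mg/kg by the intravenous route:
- compound 1 `O=C(O)CCn1c(=O)oc2cc(OCC3CC3)c(Cl)cc21`: 90.2%
- compound 2 `Cc1ccc([C@@H](C)Oc2cc3onc(CCC(=O)O)c3cc2Cl)nn1`: 93.3%

Compound 2, at 93.3%, stands within the usual scatter of compound 1, at 90.2%, so this assay does not separate the two. Compound 3 `C[C@@H](Oc1cc2onc(CCC(=O)O)c2cc1Cl)c1ccccn1` differs from compound 2 in one place, on a saturated chain carbon bound to an oxygen on an aromatic ring and a saturated chain carbon, where pyridin-2-yl stands in place of 6-methylpyridazin-3-yl: pyridin-2-yl in place of 6-methylpyridazin-3-yl on a saturated chain carbon bound to an oxygen on an aromatic ring and a saturated chain carbon. Among the compounds with values here, no measured pair shows this change alone. The two measured compounds differ in more than one place, yet their values lie within the scatter, so only a small step towards more binding is expected, probably none beyond the scatter. The estimated step is a 1.2-fold lower unbound fraction from compound 2 to compound 3 (0.09 log units; within the scatter). The expected value for compound 3 is 94.5%, with an estimated range of 89% to 97.5%.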

Compound 3, plasma protein binding: 97.8%
Estimate against measurement, compound 3: 2.5-fold (0.40 log units) (unbound fraction) above; the measured number lies above the stated range.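

In this assay, within the data shown here, putting pyridin-2-yl in place of 6-methylpyridazin-3-yl on a saturated chain carbon bound to an oxygen on an aromatic ring and a saturated chain carbon gives a 3.0-fold lower unbound fraction from compound 2 to compound 3 (0.48 log units; beyond the scatter), the first change in a single place that can be read here. It shows that plasma protein binding responds to the group at this position, and that this one change is enough to carry the value beyond the scatter. No measurement at hand explains the step.

The change alters the ring nitrogen count and removes the methyl group at once, so the pair cannot say how much each part contributes. Nor do these compounds show whether phenyl or a methyl-bearing pyridin-2-yl at this position would follow the same direction, or whether the step would hold on the core of compound 1.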